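This account rests on a few compounds, and the source may have more. Where it says the series, first, only, none or still open, it means among the compounds named here.

Measured in an assay on HEK293 cells for inhibition of cytochrome P450 1A1 (Homo sapiens), read by fluorescence, with stated times of 30 min and 60 min; on this read-out lower numbers stand for stronger inhibition and higher numbers for weaker inhibition:
- compound 1 `COc1ccc(/C=C/C(=O)c2ccncc2)cc1` gives 6610 nM
- compound 2 `COc1ccccc1/C=C/C(=O)c1ccncc1` gives 610 nM
- compound 3 `COc1cccc(/C=C/C(=O)c2ccncc2)c1` gives 620 nM

Compound 3 stands second highest of the three numbers. Its nearest neighbour is compound 2, whose number lies within the scatter of that of compound 3. Compound 1 sits furthest away, with a number beyond the scatter above that of compound 3.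

Compound 4 `COc1ccc(/C=C/C(=O)c2ccncc2)cc1OC` is not yet measured in this assay. It differs from compound 3 in one place: methoxy in place of hydrogen on an aromatic carbon. Within the data shown here, no measured pair shows this change, so there is no step to lean on. The expected step in this assay from compound 3 to compound 4 is a 3.2-fold higher number from compound 3 to compound 4 (0.51 log units; beyond the scatter), a move toward a higher number, likely beyond the scatter. Compound 4 is therefore estimated at 2000 nM, within 600 nM to 7000 nM.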

Compound 4, half-maximal inhibitory concentration: 420 nM
Compound 4: the middle estimate sits 4.8-fold (0.68 log units) above what was measured; the measured number lies below the stated range.
By their numbers in this assay, from the lowest: compounds 4, 2 and 3 (each within the scatter of the next); then compound 1.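

In this assay, methoxy in place of hydrogen para to a large group and ortho to a methoxy group gives a 1.5-fold lower number from compound 3 to compound 4 (0.17 log units; within the scatter) at this position. A second methoxy on the core also gives a 16-fold lower number from compound 1 to compound 4 (1.20 log units; beyond the scatter) here, so a methoxy para to a large group does not alone go with a high number. Nothing measured here accounts for either step.

Open, as far as these compounds go, is whether a hydroxyl, an amine or a longer ether chain such as ethoxy at this position would give a similar number. Also open, from the compounds shown here alone, is whether a second methoxy matters on compound 2.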